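The compounds below may be only part of what the source reports. "The series", "measured", "known", "first", "only" and "open" are said of these compounds alone.

Measured compounds in a physicochemical assay for solubility, read by LC-MS, in phosphate buffer, measured as thermodynamic solubility, with a stated time of 24 h, at pH 7.4; on this read-out lower numbers stand for lower solubility and higher numbers for higher solubility:

compound 1 `Cn1cc(-c2cnc3[nH]cc(-c4ccccc4C#N)c3c2)cn1`, compound 1 gives 11000 nM
compound 2 `Cn1cc(-c2cnc3[nH]cc(-c4ccccc4)c3c2)cn1`, compound 2 gives 20000 nM
compound 3 `COc1ccc(-c2c[nH]c3ncc(-c4cnn(C)c4)cc23)cc1`, compound 3 gives 5000 nM

Compound 2 holds the highest of the three numbers; compound 1 sits nearest to it and compound 3 furthest. The step from compound 1 to compound 2 is a 1.8-fold higher number from compound 1 to compound 2 (0.26 log units; within the scatter), so the two values are not separable. The step from compound 2 to compound 3 is a 4.0-fold lower number from compound 2 to compound 3 (0.60 log units; beyond the scatter), a modest but real loss.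

Compound 4 `Cn1cc(-c2cnc3[nH]cc(-c4cccc([N+](=O)[O-])c4)c3c2)cn1` differs from compound 2 by nitro in place of hydrogen on an aromatic carbon. Both measured steps concern a single substituent on the same phenyl ring of the shared core: with cyano present the number is indistinguishable from the unsubstituted parent, with methoxy present it is modestly lower. Neither step gave a higher number than compound 2, so for compound 4 the expectation in this assay is a small drop or none beyond the scatter; the estimated step from compound 2 to compound 4 is a 2.5-fold lower number from compound 2 to compound 4 (0.40 log units; beyond the scatter). Compound 4 is therefore expected near 8000 nM, with a range from 3500 nM to 18000 nM.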

Compound 4, solubility: 2000 nM
Compound 4: middle estimate off by 4.0-fold (0.60 log units), on the high side; measured number below the stated range.
By their numbers in this assay, from the lowest: compound 4; then compound 3; then compounds 1 and 2 (each within the scatter of the next).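

In this assay, nitro on an aromatic carbon of a six-membered aromatic ring of carbon only, meta to a large group, gives a 10-fold lower number from compound 2 to compound 4 (1.00 log units; beyond the scatter), the largest of the steps from the unsubstituted parent. This shows that a single substituent on this ring can cost far more than a 4.0-fold lower number from compound 2 to compound 3 (0.60 log units; beyond the scatter), while a 1.8-fold higher number from compound 1 to compound 2 (0.26 log units; within the scatter) stays within the scatter. Among the four compounds, compound 4 now holds the lowest number, and none of the three substituents gives a number above that of compound 2. Nothing measured here accounts for the size of this drop.

Group and ring place change together across compounds 1, 3 and 4, so the contribution of each stays unseparated. On these data alone, whether an amine or a carboxylic acid at this place would stay near compound 2 or fall as far as nitro remains open.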